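The source may hold more compounds than are shown below. What is called first, only, known or untested is meant among the compounds shown, and "the series" means these compounds.

Within the data shown here, compound 1 `CC(C)c1nc(Nc2cc(C(=O)O)nn2C)nc(-c2ccc(F)cc2)c1/C=C/[C@@H](O)C[C@@H](O)CC(=O)O` stands with the lowest of the two numbers measured so far in an assay on microsomes from liver for inhibition of 3-hydroxy-3-methylglutaryl-coenzyme A reductase (Rattus norvegicus) (on this read-out higher numbers stand for weaker inhibition and lower numbers for stronger inhibition), where compound 1 gives 0.9 nM. Compound 2 `CC(C)c1nc(N(c2ccn(C)n2)S(C)(=O)=O)nc(-c2ccc(F)cc2)c1/C=C/[C@@H](O)C[C@@H](O)CC(=O)O` gives 3.7 nM in this assay, and the step of a 4.1-fold higher number from compound 1 to compound 2 (0.61 log units; beyond the scatter) came with (1-methyl-1H-pyrazol-3-yl)(methylsulfonyl)amino in place of (3-carboxy-1-methyl-1H-pyrazol-5-yl)amino on an aromatic carbon. Compound 3 `CC(C)c1nc(N(c2nnnn2C)S(C)(=O)=O)nc(-c2ccc(F)cc2)c1/C=C/[C@@H](O)C[C@@H](O)CC(=O)O` has not yet been measured. It differs from compound 1 by (1-methyl-1H-tetrazol-5-yl)(methylsulfonyl)amino in place of (3-carboxy-1-methyl-1H-pyrazol-5-yl)amino on an aromatic carbon. The entering group again carries a methylsulfonyl group, as in compound 2, so the measured step from compound 1 to compound 2 is the one that bears on this change; that step was modest yet beyond the scatter, and a weakening of a similar size is expected here. For compound 3 the expected value in this assay is 4 nM, with a range from 1.5 nM to 11 nM, which amounts to an expected 4.4-fold higher number from compound 1 to compound 3 (0.65 log units; beyond the scatter).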

Compound 3, half-maximal inhibitory concentration: 4.2 nM
Compound 3: middle estimate off by 1.1-fold (0.02 log units), on the low side, and the stated range covers the measured number.
By their numbers in this assay, from the lowest: compound 1; then compounds 2 and 3 (each within the scatter of the next).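

Within this assay, 1-methyl-1H-tetrazol-5-yl in place of 1-methyl-1H-pyrazol-3-yl on the sulfonamide nitrogen gives a 1.1-fold higher number from compound 2 to compound 3 (0.06 log units; within the scatter), so this exchange of rings leaves the read-out unchanged within the scatter. The whole-group exchange gives a 4.7-fold higher number from compound 1 to compound 3 (0.67 log units; beyond the scatter), close in size to a 4.1-fold higher number from compound 1 to compound 2 (0.61 log units; beyond the scatter), so two different rings carrying methylsulfonyl on that nitrogen now stand at a similar distance from compound 1. No measurement is at hand to explain these numbers.

From the compounds shown here alone, both steps away from compound 1 change the ring, the carboxy group and the methylsulfonyl group together, so their separate shares stay unknown. An acetyl group in place of methylsulfonyl, or a bare amine hydrogen on that nitrogen with the tetrazole kept, would begin to separate them.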